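Ring swaps at the ether chain end

The source may report more compounds than this note shows. Statements on the series, on what has been measured and on what is new or still open speak of the compounds shown alone.

For the measured compounds named here, compound 2 `O=C1N=C(O)S/C1=C\c1ccc(OCCC2CCCC2)cc1` gives 116 nM in an assay for inhibition of 15-hydroxyprostaglandin dehydrogenase [NAD(+)] (Homo sapiens), read by fluorescence and spectrophotometry (a higher number here means a weaker inhibitor, a lower number a stronger inhibitor), the higher of the two numbers so far, though compound 1 `O=C1N=C(O)S/C1=C\c1ccc(OCCc2ccsc2)cc1` with 60 nM is not separated from it: the step of a 1.9-fold higher number from compound 1 to compound 2 (0.29 log units; within the scatter) lies within the scatter. Compound 3 `Cc1ccc(COc2ccc(/C=C3\SC(O)=NC3=O)cc2)cc1` differs from compound 2 by 4-methylphenyl in place of cyclopentylmethyl on a saturated chain carbon bound to an oxygen on an aromatic ring. Going by the values given here, the only measured step also exchanged an aromatic ring for a saturated one further along the chain and stayed within the scatter, so for compound 3 a step in this assay no larger than the scatter is expected, if anything toward a lower number. Compound 3 is estimated at 80 nM, between 30 nM and 250 nM, a step of a 1.5-fold lower number from compound 2 to compound 3 (0.16 log units; within the scatter).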

Compound 3, half-maximal inhibitory concentration: 232 nM
For compound 3 the middle estimate is 2.9-fold (0.46 log units) below the measured one; the range from low to high includes it.
By their numbers in this assay, from the lowest: compounds 1, 2 and 3 (each within the scatter of the next, the first and the last beyond it).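

In this assay the step of a 2.0-fold higher number from compound 2 to compound 3 (0.30 log units; within the scatter) stays within the scatter, so on a saturated chain carbon bound to an oxygen on an aromatic ring, 4-methylphenyl is not separated from cyclopentylmethyl. For the compounds shown here, the step of a 3.9-fold higher number from compound 1 to compound 3 (0.59 log units; beyond the scatter) is modest but is the first beyond the scatter, showing that this position can register a swap of (thiophen-3-yl)methyl for 4-methylphenyl. No available evidence bears on the origin of this step.

Still open, as far as these compounds go, is how an amine or a carboxylic acid at the chain end would read in this assay, and whether a longer chain would keep the number of compound 1.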